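The compounds below may be only part of what the source reports. "The series", "measured", "known", "first", "only" and "open" are said of these compounds alone.

Measured in a functional assay on MCF7 cells (Homo sapiens) for antiproliferative activity, read by MTT assay, with a stated time of 48 h; a lower number here means a stronger inhibitor, a higher number a weaker inhibitor:
- compound 1 `CCN(CC)CC(=O)Nc1ccc(Nc2cc(Cl)nc(-c3ccc(OC)cc3)n2)cc1`: > 40000 nM (a limit, not a number)
- compound 2 `COc1ccc(-c2nc(Cl)cc(Nc3ccc(NC(=O)CN4CCCC4)cc3)n2)cc1`: 23400 nM

Compound 1 has no exact position on the scale, only a limit. It stands at the limit of > 40000 nM in this assay, at which 1 of the 2 values shown sits.

Compound 3 `CCN(CC)CC(=O)Nc1ccc(Nc2nc(-c3ccc(OC)cc3)nc(Cl)c2-c2ccccc2)cc1` keeps the side chain of compound 1 and changes the shared core, with phenyl in place of hydrogen on an aromatic carbon.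

For the measured compounds named here, only one measured step is available, an at least 1.7-fold lower number from compound 1 to compound 2 (0.23 log units; that floor lies within the scatter). That step swaps diethylamino for pyrrolidin-1-yl on the side chain, so it lies elsewhere in the molecule, and its floor is within the scatter. No measured compound carries a group at the new place, so the size and direction of this change are not shown by the data.

No step beyond the scatter is therefore expected in this assay, and a result reported only as a limit remains quite possible. The estimated change is an at least 1.1-fold lower number from compound 1 to compound 3 (0.05 log units; that floor lies within the scatter). For compound 3 the estimated value is 35000 nM, with an expected range from 14000 nM to 80000 nM.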

Compound 3, half-maximal inhibitory concentration: > 40000 nM
Compound 3 ended at the assay's limit (the forecaster's own chance of this, stated with the estimate: 50%); at least 1.1-fold (0.05 log units) between middle value and limit.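

In this assay compound 3 gives > 40000 nM, a limit and not a number. Compound 1 also stands only at a limit, so no step from compound 1 to compound 3 can be read: the limit of > 40000 nM in this assay, at which 2 of the 3 values shown sit.

The compounds shown leave open whether phenyl in place of hydrogen on an aromatic carbon changes the number at all, and in which direction.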